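Bromo to fluoro on a near-inactive benzylidene pair

This account rests on a few compounds, and the source may have more. Where it says the series, first, only, none or still open, it means among the compounds named here.

compound 1 `O=C1NC(=S)/C(=C/c2ccccc2Br)S1`: 3.14%
compound 2 `O=C1NC(=S)/C(=C/c2cccc(Cl)c2)S1`: -0.36%

In a functional assay on HEp-2 cells (Homo sapiens) for cytotoxicity, read by MTT assay, with a stated time of 72 h, tested at 1.25 ug/mL (a lower number here means less inhibition of growth, a higher number more inhibition of growth at the concentration tested), compound 1 gives 3.14%, the top of only two numbers shown, and compound 2 gives -0.36%, a gap that lies within the scatter. Compound 3 `O=C1NC(=S)/C(=C/c2ccccc2F)S1` differs from compound 1 by fluoro in place of bromo on an aromatic carbon. Among the measured compounds shown here, no step between measured compounds gauges this change, and both measured numbers sit near zero. The step from compound 1 to compound 3 is therefore expected to be a number 1.1 percentage points lower from compound 1 to compound 3 (within the scatter), none beyond the scatter. Compound 3 is estimated at 2%, within -8% to 12%.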

Compound 3, percent growth inhibition at one concentration: -8.34%
The estimate for compound 3 lay 10.3 percentage points above the measured number, and the stated range ends above it.
By their numbers in this assay, from the lowest: compounds 3, 2 and 1 (each within the scatter of the next, the first and the last beyond it).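

Among the compounds shown here, this is the first step gauged at this position, on an aromatic carbon ortho to a group of 8 heavy atoms. In this assay, fluoro in place of bromo gives a number 11.5 percentage points lower from compound 1 to compound 3 (beyond the scatter), so even this one-atom exchange, with no change in hydrogen-bond donors, acceptors or net charge, moves the number by a modest step. Nothing shown accounts for the step. As far as these compounds go, whether a methyl group or an amine on this carbon would read closer to compound 1 or compound 3 stays open. So does whether the same exchange elsewhere on the ring would give a similar step.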